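From Ethyl to Hydroxy on the Shared Core

The source may report more compounds than this note shows. Statements on the series, on what has been measured and on what is new or still open speak of the compounds shown alone.

In an ADME assay on HEp-2 cells (Homo sapiens) for cytotoxicity (on this read-out lower numbers stand for higher toxicity in this test and higher numbers for lower toxicity in this test), compound 2 (`CCc1cc2ccccc2n(Cc2nc3ccccc3n2CCCCF)c1=O`) gives 85100 nM, the second highest of three numbers. Compound 2 stands above compound 1 (`O=c1c(Br)cc2ccccc2n1Cc1nc2ccccc2n1CCCCF`) at 26200 nM. Compound 2 stands below compound 3 (`CN1C(=O)N(Cc2nc3ccccc3n2CCCCO)c2ccccc2S1(=O)=O`) at 219000 nM. Compound 4 (`O=c1c(O)cc2ccccc2n1Cc1nc2ccccc2n1CCCCF`) has hydroxy in place of ethyl on an aromatic carbon. Among the measured compounds shown here, the one measured step at that carbon is a 3.2-fold higher number from compound 1 to compound 2 (0.51 log units; beyond the scatter), modest and beyond the scatter, with ethyl in place of bromo. Compound 3 differs in more than one place, and no hydroxy at that carbon has been measured. No firm direction follows, so in this assay no step beyond the scatter is expected. The expected change is a 1.2-fold higher number from compound 2 to compound 4 (0.07 log units; within the scatter). Compound 4 is estimated at 100000 nM, within an expected range of 40000 nM to 250000 nM.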

Compound 4, half-maximal cytotoxic concentration: 20200 nM
Compound 4: middle estimate off by 5.0-fold (0.69 log units), on the high side; measured number below the stated range.
By their numbers in this assay, from the lowest: compounds 4 and 1 (each within the scatter of the next); then compound 2; then compound 3.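

In this assay the aromatic carbon responds to hydroxy in place of ethyl (a 4.2-fold lower number from compound 2 to compound 4 (0.62 log units; beyond the scatter)), so the earlier rise with ethyl is not matched by this smaller group. Hydroxy and bromo at this carbon give numbers within the scatter of each other (a 1.3-fold lower number from compound 1 to compound 4 (0.11 log units; within the scatter)), which leaves ethyl as the one of the three groups set apart. Nothing at hand accounts for this result. As far as these compounds go, whether an amine, a methoxy group or a longer chain at this carbon would side with ethyl or with hydroxy and bromo stays open.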